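A few compounds are considered here, and "the series" means these few. Any claim that something is new, unique, unknown or untested is made for them only; others in the source may bear on it.

Working notes on the series. In a functional assay on MT4 cells (Homo sapiens) for antiproliferative activity, read by MTT assay, with a stated time of 96 h (a lower number here means a stronger inhibitor, a higher number a weaker inhibitor), compound 1 (`CCN(CC)c1ccc(N2C(=O)NC3(CSC4=C3C(=O)c3ncccc3C4=O)C2=O)cc1`) gives 8 nM. Compound 3 (`O=C1NN(c2ccc([N+](=O)[O-])cc2)C(=O)C2(CSC3=C2C(=O)c2ncccc2C3=O)N1`) gives 5 nM, which places compound 1 and compound 3 within the scatter of each other, so no order can be drawn between them. Compound 2 (`O=C1NNC(=O)C2(CSC3=C2C(=O)c2ncccc2C3=O)N1`) stands well apart from both, and its repeat entries agree closely at 550 nM; 500 nM; 550 nM (3 entries). Compound 1 therefore belongs to the low-number pair of the series, alongside compound 3.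

The change under consideration leads to compound 4 (`CCCc1ccc(N2C(=O)NC3(CSC4=C3C(=O)c3ncccc3C4=O)C2=O)cc1`), with propyl in place of diethylamino on an aromatic carbon, para to a large group: propyl in place of diethylamino on an aromatic carbon. The shared core is kept. Within the data shown here, no measured pair isolates a change at this place, so there is no direct precedent for the size of the step. Among the measured compounds shown here, the only guide is the shared low range of compound 1 at 8 nM and compound 3 at 5 nM. In this assay no step beyond the scatter is expected, with a slight lean toward a higher number. The expected change is small, a 1.5-fold higher number from compound 1 to compound 4 (0.18 log units; within the scatter). For compound 4 the estimated value is 12 nM, with an expected range of 4 nM to 40 nM.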

Compound 4, half-maximal inhibitory concentration: 1 nM
Estimate against measurement, compound 4: 12-fold (1.08 log units) above; the measured number lies below the stated range.
By their numbers in this assay, from the lowest: compound 4; then compounds 3 and 1 (each within the scatter of the next).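

In this assay, the aromatic carbon para to a large group turns out to be sensitive to what it carries: propyl in place of diethylamino gives an 8.0-fold lower number from compound 1 to compound 4 (0.90 log units; beyond the scatter). Among these compounds, this is the first step that isolates a change at this place, and it shows that the low range shared by the earlier compounds is not a floor for this substituent position, since a chain with fewer heavy atoms and no nitrogen brings the number further down. The step also stands well clear of how closely repeat entries agree in this readout: the several entries of compound 2 in this assay, 550 nM; 500 nM; 550 nM (3 entries)

Going by these compounds, what stays open is which part of the exchange matters, as the loss of the nitrogen and the change in the size of the group occur together in this one pair and neither can be read alone. Also open, on these data alone, is how a longer chain such as butyl, or a smaller amine such as dimethylamino, would stand at this place in this assay, which would separate chain length from the presence of the nitrogen.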